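Methyl for methoxy on compound 1

The compounds below may be only part of what the source reports. "The series", "measured", "known", "first", "only" and "open" are said of these compounds alone.

Measured compounds:
compound 1 `COc1ccc(OCCCON2C(N)=NC(N)=NC23CCOCC3)cc1`: 1500 nM
compound 2 `NC1=NC2(CCSCC2)N(OCCCOc2ccc(Br)cc2)C(N)=N1`: 20 nM
compound 3 `NC1=NC2(CCSCC2)N(OCCCOc2cccc(Cl)c2Cl)C(N)=N1`: 1 nM

In a functional assay on HCT-116 cells (Homo sapiens) for antiproliferative activity, read by MTT assay, with a stated time of 72 h (a lower number here means a stronger inhibitor, a higher number a weaker inhibitor), compound 1 stands highest of the three numbers. Going by the values given here, compound 2 sits well under it, and compound 3 further still; both carry a different core and a halogenated aryl group, so no single-point step connects them to compound 1, and their values only show that the present series reaches far lower numbers than compound 1.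

Compound 4 `Cc1ccc(OCCCON2C(N)=NC(N)=NC23CCOCC3)cc1` keeps the core and the three-carbon linker of compound 1 and differs only in the aryl ring: methyl in place of methoxy on an aromatic carbon.

Among the compounds with values here, only one step is known, a 20-fold lower number from compound 2 to compound 3 (1.30 log units; beyond the scatter). It changes the aryl substitution pattern on the same oxygen on a saturated carbon, but on the other core and between halogens, not between methoxy and methyl; it bears on compound 4 only loosely, as a sign that the aryl group can move this assay strongly. Within the data shown here, for a methoxy to methyl swap no measured pair exists, so the expected step from compound 1 to compound 4 is none beyond the scatter, with a wide range to cover the possibility of a real shift in either direction.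

Compound 4 is therefore estimated at 1200 nM, within 350 nM to 4500 nM, which means an expected step of a 1.3-fold lower number from compound 1 to compound 4 (0.10 log units; within the scatter).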

Compound 4, half-maximal inhibitory concentration: 2390 nM
Compound 4: middle estimate off by 2.0-fold (0.30 log units), on the low side; measured number inside the range.
By their numbers in this assay, from the lowest: compound 3; then compound 2; then compounds 1 and 4 (each within the scatter of the next).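

In this assay, 4-methylphenyl in place of 4-methoxyphenyl gives a 1.6-fold higher number from compound 1 to compound 4 (0.20 log units; within the scatter), so on the core of compound 1 this place, para to a large group, takes methyl for methoxy, with one hydrogen-bond acceptor fewer, without a shift that can be told from the scatter. The aryl group can still move this assay strongly on the other core, as a 20-fold lower number from compound 2 to compound 3 (1.30 log units; beyond the scatter) shows, but that step lies beyond the scatter and involves halogens, whereas this one, with methoxy and methyl, does not leave it. No measurement at hand bears on this result.

Open, as far as these compounds go, is whether the 4-bromophenyl of compound 2 or the 2,3-dichlorophenyl of compound 3 would lower the number on the core of compound 1, and whether an amine or a carboxylic acid at this same place would move it beyond the scatter. Also open, from the compounds shown here alone, is whether methyl for methoxy reads the same on the core of compound 2, and whether a longer chain in place of the present linker changes the picture.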